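Shortening an Amino Substituent: From Compound 2 to Compound 3

The source may hold more compounds than are shown below. What is called first, only, known or untested is meant among the compounds shown, and "the series" means these compounds.

Compound 1 `CN(C)c1ncnc2c1ncn2Cc1c(F)cccc1Cl` gives 5 mg/kg in a functional assay on the whole organism with Rattus norvegicus as the target, in the maximal electroshock model; on this read-out higher numbers stand for an effect only at larger amounts of compound and lower numbers for an effect already at smaller amounts.
Compound 2 `CCCNc1ncnc2c1ncn2Cc1ccccc1F` gives 5.1 mg/kg in this assay.

Compound 2 shows the highest of the two numbers, yet its gap to compound 1 lies within the scatter, so the two compounds cannot be told apart on these values. Compound 3 `Nc1ncnc2c1ncn2Cc1ccccc1F` differs from compound 2 by hydrogen in place of propyl on a nitrogen on an aromatic ring. Among the compounds with values here, no measured pair here shows what such a change does. In this assay the step of a 1.6-fold higher number from compound 2 to compound 3 (0.20 log units; within the scatter) is expected to be small, leaning toward a higher number, and may not exceed the scatter. Compound 3 is expected to give 8 mg/kg, between 3 mg/kg and 25 mg/kg.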

Compound 3, dose for half-maximal effect: 4.5 mg/kg
Compound 3: the middle estimate sits 1.8-fold (0.25 log units) above what was measured; low and high end bracket the measured number.
By their numbers in this assay, from the lowest: compounds 3, 1 and 2 (each within the scatter of the next).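

Hydrogen in place of propyl on this nitrogen gives a 1.1-fold lower number from compound 2 to compound 3 (0.05 log units; within the scatter) in this assay and so leaves the number inside the scatter. On this read-out, then, propylamino can be cut back to plain amino with no measurable loss, so the propyl chain is not required for the effect of compound 2. Nothing available explains this result. Open, as far as these compounds go, is whether a longer chain such as hexyl, or a cyclic amine such as morpholine, on this nitrogen would also leave the number unchanged.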